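Hydroxy to hydroxymethyl on two related sulfonamide cores

This account rests on a few compounds, and the source may have more. Where it says the series, first, only, none or still open, it means among the compounds named here.

Compound 1 `NS(=O)(=O)c1ccc(SCCO)c(F)c1` and compound 2 `NS(=O)(=O)c1ccc(SCCCO)c(F)c1` share one core; compound 3 `Nc1cc(S(N)(=O)=O)ccc1S(=O)(=O)CCO` and compound 4 `Nc1cc(S(N)(=O)=O)ccc1S(=O)(=O)CCCO` share another. The difference between the two cores is not broken down here.

In a physicochemical assay for solubility, at pH 7.4 (on this read-out higher numbers stand for higher solubility and lower numbers for lower solubility), compound 1 gives 6000 ug/mL and compound 2 gives 900 ug/mL. The change between them is hydroxymethyl in place of hydroxy on a saturated chain carbon, two bonds along the chain from a sulfur and it made a 6.7-fold lower number from compound 1 to compound 2 (0.82 log units; beyond the scatter). In this assay compound 3 gives 13200 ug/mL, the highest of the three measured numbers, with both other compounds beyond the scatter below it.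

Compound 4 is not yet measured. Its difference from compound 3 is hydroxymethyl in place of hydroxy on a saturated chain carbon, two bonds along the chain from a sulfonyl sulfur. Among the compounds with values here, this is the same kind of change as the one from compound 1 to compound 2, not the same one: in compound 1 the chain carbon is two bonds along the chain from a sulfur, in compound 3 it is two bonds along the chain from a sulfonyl sulfur. Only one earlier instance of this kind of change exists among these compounds, and it sits on a different core, so the expectation rests on that single step alone.

In this assay compound 4 is expected to give 2500 ug/mL, with a plausible range from 1000 ug/mL to 7000 ug/mL. That estimate means an expected step of a 5.3-fold lower number from compound 3 to compound 4 (0.72 log units; beyond the scatter), set a little smaller than the earlier one because a 6.7-fold lower number from compound 1 to compound 2 (0.82 log units; beyond the scatter) was recorded with the plain sulfur rather than the sulfonyl sulfur along the chain.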

Compound 4, solubility: 8400 ug/mL
Estimate against measurement, compound 4: 3.4-fold (0.53 log units) below; the whole stated range lies below it.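

In this assay, the same kind of change gave a 6.7-fold lower number from compound 1 to compound 2 (0.82 log units; beyond the scatter) on the first core and a 1.6-fold lower number from compound 3 to compound 4 (0.20 log units; within the scatter) on the second, so a step beyond the scatter on the core of compound 1 did not reappear as one on the core of compound 3. The size of the step therefore did not carry from one core to the other in this pair of pairs, but a single step within the scatter does not show that the change never matters on the core of compound 3, and with one pair per core the contrast cannot be tied to the plain sulfur, the sulfonyl sulfur or any other part of the difference between the cores. No measurement shown here bears on the reason for the contrast.

On these data alone, whether the same contrast between the cores in this assay holds for a longer chain, such as one that ends in the same hydroxy group after further carbons, remains open. Also open is what a carboxylic acid or an amine would do in place of the hydroxy on either core, since the steps shown cover only the hydroxy to hydroxymethyl change.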